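From chloro to fluoro on compound 1

The compounds below may be only part of what the source reports. "The series", "measured", "known", "first", "only" and "open" are said of these compounds alone.

compound 1 `COc1ccc(/C=C(\C)C(=O)/C=C/c2ccccc2Cl)cc1` gives 74300 nM
compound 2 `COc1ccc(/C=C(\C)C(=O)/C=C/c2cccc(Cl)c2Cl)cc1` gives 119000 nM
compound 3 `COc1ccc(/C=C(\C)C(=O)/C=C/c2c(Cl)cccc2Cl)cc1` gives 65700 nM

These values come from an ADME assay on Vero cells (Chlorocebus sabaeus) for cytotoxicity, read by MTT assay, with a stated time of 72 h (on this read-out higher numbers stand for lower toxicity in this test and lower numbers for higher toxicity in this test), and compound 1 stands within the scatter of both others. Compound 4 `COc1ccc(/C=C(\C)C(=O)/C=C/c2ccccc2F)cc1` is not yet measured and differs from compound 1 by fluoro in place of chloro on an aromatic carbon with fluoro in place of chloro on an aromatic carbon, ortho to a large group. Among the measured compounds shown here, no measured step makes this exchange. The nearest evidence is chloro in place of hydrogen, and a 1.6-fold higher number from compound 1 to compound 2 (0.20 log units; within the scatter) and a 1.1-fold lower number from compound 1 to compound 3 (0.05 log units; within the scatter) are both small, so little is expected here. The expected outcome is a 1.0-fold higher number from compound 1 to compound 4 (0.02 log units; within the scatter) and thus no step beyond the scatter. For compound 4 the estimate is 78000 nM and the expected range runs from 38000 nM up to 150000 nM as the two ends of that estimate.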

Compound 4, half-maximal cytotoxic concentration: 81200 nM
Estimate against measurement, compound 4: 1.0-fold (0.02 log units) below, within the range that was stated.
By their numbers in this assay, from the lowest: compounds 3, 1, 4 and 2 (each within the scatter of the next).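

In this assay, among the compounds shown here, the exchange of 2-chlorophenyl for 2-fluorophenyl gives a 1.1-fold higher number from compound 1 to compound 4 (0.04 log units; within the scatter) and is the first step that replaces the chloro at this place, whereas the earlier steps only added a second chloro to the ring. At this place, on an aromatic carbon ortho to a large group, one halogen therefore reads like the other in this test. No measurement given here accounts for this result. The compounds shown leave open how an amine or a carboxylic acid would read at this place. They also leave open whether the same exchange would read alike with a second chloro on the ring, as in compound 2 or compound 3.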